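The source may hold more compounds than are shown below. What is called first, only, known or untested is meant among the compounds shown, and "the series" means these compounds.

For the measured compounds named here, compound 1 `Cc1ccc(S(=O)(=O)/N=C(/CCNC2=CC(=O)c3ccccc3C2=O)Nc2cccc(C)c2)cc1` is one of two compounds measured in an ADME assay on HEK293 cells (Homo sapiens) for cytotoxicity, read by MTT assay, with a stated time of 48 h (a higher number here means a weaker inhibitor, a lower number a stronger inhibitor), where compound 1 gives 56200 nM, the lowest of the two numbers. Going by the values given here, its only neighbour is compound 2 `Cc1ccc(S(=O)(=O)/N=C(/CCNC2=CC(=O)c3ccccc3C2=O)Nc2cccc(C(F)(F)F)c2)cc1`, which in this assay gives 91500 nM; the step of a 1.6-fold higher number from compound 1 to compound 2 (0.21 log units; within the scatter) is a trifluoromethyl in place of a methyl on an aromatic carbon, and it stays within the scatter.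

Compound 3 `Cc1ccc(S(=O)(=O)/N=C(/CCNC2=CC(=O)c3ccccc3C2=O)NC2CCCCC2)cc1` has not yet been measured in this assay. Its difference from compound 1 is cyclohexyl in place of 3-methylphenyl on an amine nitrogen. Among the compounds with values here, no measured step touches this part of the shared core: the single step known, from compound 1 to compound 2, changes only a substituent on the 3-methylphenyl that is now removed altogether, and that step was itself within the scatter. The data therefore offer no ground for expecting a step in this assay beyond the scatter in either direction, only a wide uncertainty around the number of compound 1.

On that basis the estimate for compound 3 in this assay is 60000 nM, expected to fall between 25000 nM and 145000 nM, which corresponds to an expected step of a 1.1-fold higher number from compound 1 to compound 3 (0.03 log units; within the scatter).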

Compound 3, half-maximal inhibitory concentration: 50100 nM
Compound 3: middle estimate off by 1.2-fold (0.08 log units), on the high side, and the stated range covers the measured number.
By their numbers in this assay, from the lowest: compounds 3, 1 and 2 (each within the scatter of the next).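

In this assay, the amine nitrogen that carries the 3-methylphenyl of compound 1 also tolerates a ring that is not aromatic: cyclohexyl in its place gives a 1.1-fold lower number from compound 1 to compound 3 (0.05 log units; within the scatter) and, set against the 3-(trifluoromethyl)phenyl of compound 2, gives a 1.8-fold lower number from compound 2 to compound 3 (0.26 log units; within the scatter) at this same place. The earlier pair varied only a substituent on the aromatic ring, whereas here the whole aromatic ring is exchanged and all three compounds still lie within the scatter of one another, so among these compounds the read-out does not depend on that ring being aromatic. No measurement on hand bears on why this exchange leaves the number within the scatter.

The compounds shown leave open whether this nitrogen would stay as indifferent with something other than a six-membered carbon ring on it, such as a straight alkyl chain, a chain ending in an amine or one ending in a carboxylic acid. Going by these compounds, all three also share the rest of the core unchanged, so what the cytotoxicity read-out does when those other parts are altered remains unknown.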